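A few compounds are considered here, and "the series" means these few. Any claim that something is new, unique, unknown or untested is made for them only; others in the source may bear on it.

Measured in a functional assay on HEY cells (Homo sapiens) for cytotoxicity, read by MTT assay, with a stated time of 72 h; on this read-out higher numbers stand for weaker inhibition and lower numbers for stronger inhibition
compound 1 `N[C@H]1CC[C@H](Nc2c(C(=O)NCc3ccc(F)cc3)nc(Br)c3cccnc23)CC1` gives "not determined" (no result reported)
compound 2 `N[C@H]1CC[C@H](Nc2c(C(=O)NCc3ccc(Cl)cc3)nc(Br)c3cccnc23)CC1` gives 1000 nM
compound 3 `N[C@H]1CC[C@H](Nc2c(C(=O)NCc3cccs3)nc(Br)c3cccnc23)CC1` gives 11000 nM

Compound 3 at 11000 nM holds the higher of the two available numbers, and compound 1 offers no number for comparison. Compound 4 `N[C@H]1CC[C@H](Nc2c(C(=O)Nc3ccccc3)nc(Br)c3cccnc23)CC1` has phenyl in place of (thiophen-2-yl)methyl on an amide-type nitrogen. Going by the values given here, one measured step bears on this change: an 11-fold higher number from compound 2 to compound 3 (1.04 log units; beyond the scatter) was large and shows that this part of the series can move the number well beyond the scatter. Among the compounds with values here, no measured compound carries phenyl on that nitrogen, so the range stays wide. A moderate move towards a lower number is expected in this assay and the expected step is a 1.8-fold lower number from compound 3 to compound 4 (0.26 log units; within the scatter) for now. Compound 4 is estimated at 6000 nM (expected range 1500 nM to 20000 nM).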

Compound 4, half-maximal inhibitory concentration: 1000 nM
Compound 4: middle estimate off by 6.0-fold (0.78 log units), on the high side; the measured number lies below the stated range.
By their numbers in this assay, from the lowest: compounds 2 and 4 (each within the scatter of the next); then compound 3.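

Phenyl directly on the amide-type nitrogen, in place of (thiophen-2-yl)methyl, gives an 11-fold lower number from compound 3 to compound 4 (1.04 log units; beyond the scatter) in this assay, so the high number of compound 3 is not general to this amide position. Phenyl in place of 4-chlorobenzyl gives no change at the digits printed from compound 2 to compound 4 (within the scatter), so neither the saturated chain carbon nor the chlorine is required for a number at this level. No evidence at hand accounts for either step. Open, from the compounds shown here alone, is how this position responds to cyclohexyl, a saturated ring, or to 2-phenylethyl, a longer chain.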